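A few compounds are considered here, and "the series" means these few. Any claim that something is new, unique, unknown or untested is made for them only; others in the source may bear on it.

Of the compounds shown here, three from this series have been tested for their ability to slow the growth of a human breast-cancer cell line, and a fourth awaits its result. Compound 1 `CCCCNS(=O)(=O)c1ccc(Nc2ncc3c(n2)N(C2CCCC2)[C@H](CC)C(=O)N3C)cc1` and compound 2 `CCCNS(=O)(=O)c1ccc(Nc2ncc3c(n2)N(C2CCCC2)[C@H](CC)C(=O)N3C)cc1` share one core and differ only at the end of a short chain: methyl in place of hydrogen on a saturated chain carbon, three bonds along the chain from a sulfonamide nitrogen. In a functional assay on MCF7 cells (Homo sapiens) for antiproliferative activity, read by CCK-8 assay, with a stated time of 72 h (on this read-out higher numbers stand for weaker inhibition of growth and lower numbers for stronger inhibition of growth), compound 2 gives 344 nM, and compound 1 gives 459 nM, so that a 1.3-fold higher number from compound 2 to compound 1 (0.13 log units; within the scatter).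

Compound 3 `CCCNC(=O)c1ccc2c(ccn2-c2ncc3c(n2)N(C2CCCC2)[C@H](CC)C(=O)N3C)c1` is built on a different core; the difference between the two cores is not broken down here. In this assay compound 3 gives 592 nM, a number that sits close to those of compound 1 and compound 2, with every gap among the three inside the usual scatter.

Compound 4 `CCCCNC(=O)c1ccc2c(ccn2-c2ncc3c(n2)N(C2CCCC2)[C@H](CC)C(=O)N3C)c1` stands to compound 3 as compound 1 stands to compound 2: methyl in place of hydrogen on a saturated chain carbon, three bonds along the chain from an amide-type nitrogen. The surroundings are not identical, since the chain hangs from an amide-type nitrogen rather than from a sulfonamide nitrogen, so this is the same kind of change, not the same change. Because a 1.3-fold higher number from compound 2 to compound 1 (0.13 log units; within the scatter), the corresponding step is expected to be small here as well, and compound 4 is expected to show a 1.2-fold higher number from compound 3 to compound 4 (0.07 log units; within the scatter) in this assay. Compound 4 is therefore estimated at 700 nM, with a likely range from 350 nM to 1400 nM.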

Compound 4, concentration for 50% growth inhibition: 634 nM
Beside the measured number, compound 4's estimate is 1.1-fold (0.04 log units) above it, and the stated range covers the measured number.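

In this assay, the same propyl to butyl lengthening on the core of compound 3 gives a 1.1-fold higher number from compound 3 to compound 4 (0.03 log units; within the scatter). Set beside the earlier step on the core of compound 1, the new step shows that this change behaves alike on both cores, with no difference that can be told from ordinary measurement noise: the same change on two cores in this assay, a 1.3-fold higher number (0.13 log units; within the scatter) from compound 2 to compound 1 and a 1.1-fold higher number (0.03 log units; within the scatter) from compound 3 to compound 4, 1.2-fold (0.10 log units) apart, within the scatter of two such steps. This supports carrying the change from one core to the other in this assay and in these two pairs only, but since each step is itself within the scatter, it shows only that the added methyl makes no clear difference on either core; a small real effect could go unseen, and two pairs say nothing about how the change would behave on a third core or in another assay.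

From the compounds shown here alone, all four compounds end in a plain propyl or butyl chain, so it remains open whether a longer chain such as hexyl would still leave the number within the scatter. Going by these compounds, it also remains open whether a group placed at the chain end, such as an amine or a carboxylic acid, would produce a step large enough to read on either core.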